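This account rests on a few compounds, and the source may have more. Where it says the series, first, only, none or still open, it means among the compounds named here.

Working notes on the series. Among the measured compounds shown here, in a functional assay on the whole organism for inhibition, with Rattus norvegicus as the target, at a dose of 10 mg/kg by the oral route (on this read-out higher numbers stand for a stronger effect at the one dose given and lower numbers for a weaker effect), compound 2 `O=C(Nc1nn[nH]n1)c1cccc(Cl)n1` gives 13%, and compound 1 `CCCCc1cccc(C(=O)Nc2nn[nH]n2)n1` gives 18%; these are the only two numbers in hand, and the step of a number 5 percentage points lower from compound 1 to compound 2 (within the scatter) lies within the scatter. Compound 3 `CCCCOc1cccc(C(=O)Nc2nn[nH]n2)n1` differs from compound 2 by butoxy in place of chloro on an aromatic carbon. For the measured compounds named here, the one measured step at this carbon, a number 5 percentage points lower from compound 1 to compound 2 (within the scatter), swapped butyl for chloro without moving this assay beyond the scatter, so for butoxy in place of chloro no step beyond the scatter is expected either. Compound 3 is expected to give 16% (range 5% to 28%). The estimated step is a number 3 percentage points higher from compound 2 to compound 3 (within the scatter).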

Compound 3, a percentage reported as inhibition, in the whole organism at one dose (the size of the read-out at that dose, not a potency): 8%
For compound 3 the middle estimate is 8 percentage points above the measured one; low and high end bracket the measured number.
By their numbers in this assay, from the lowest: compounds 3, 2 and 1 (each within the scatter of the next).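

Butoxy at this carbon gives a number 5 percentage points lower from compound 2 to compound 3 (within the scatter) and also a number 10 percentage points lower from compound 1 to compound 3 (within the scatter) in this assay, so chloro, butyl and butoxy cannot be told apart at this position on this read-out. Bringing in the oxygen of butoxy, with its hydrogen-bond acceptor, therefore gives no step beyond the scatter against either neighbour. Nothing available bears on why these numbers stay so close.

Still open, from the compounds shown here alone, is whether an amine, a carboxylic acid or a longer chain at this carbon would give a step beyond the scatter. Changes elsewhere on the shared core also remain open.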